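Removing a Ring Hydroxy: Expected Vero Cell Cytotoxicity

A few compounds are considered here, and "the series" means these few. Any claim that something is new, unique, unknown or untested is made for them only; others in the source may bear on it.

Compound 1 `CCCCC/C=C/C=C/C=C/c1c(O)ccc(O)c1C(=O)O`: 15000 nM
Compound 2 `CCCCC/C=C/C=C/C=C\c1c(O)ccc(O)c1C(=O)O`: 35000 nM

In an ADME assay on Vero cells (Chlorocebus sabaeus) for cytotoxicity, read by colorimetric assay (a higher number here means a weaker inhibitor, a lower number a stronger inhibitor), compound 1 gives the lower of the two numbers. Among the measured compounds shown here, the only measured step, a 2.3-fold higher number from compound 1 to compound 2 (0.37 log units; beyond the scatter), rests on a change in configuration alone (the fact that compounds 1 and 2 differ only in the configuration as drawn). Compound 3 `CCCCC/C=C/C=C/C=C/c1cccc(O)c1C(=O)O` differs from compound 1 in another way: hydrogen in place of hydroxy on an aromatic carbon. For the measured compounds named here, no measured step involves the loss of a hydroxy, so there is no direct guide. For compound 3 the expected step is small, a 1.2-fold higher number from compound 1 to compound 3 (0.08 log units; within the scatter), in no settled direction. Compound 3 is therefore estimated at 18000 nM, with a range from 7000 nM to 45000 nM.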

Compound 3, half-maximal inhibitory concentration: 5800 nM
Compound 3: the middle estimate sits 3.1-fold (0.49 log units) above what was measured, and the stated range ends above it.
By their numbers in this assay, from the lowest: compound 3; then compound 1; then compound 2.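

In this assay, this ring position is not silent: hydrogen in place of the hydroxy para to a hydroxy group gives a 2.6-fold lower number from compound 1 to compound 3 (0.41 log units; beyond the scatter), a move towards stronger inhibition. Among the compounds shown here, the earlier pair showed only a change in double-bond configuration, so this is the first sign that a ring substituent on the shared core matters here. For the compounds shown here, nothing measured so far explains this step. Going by these compounds, whether an amine or a methoxy group on this carbon would lower or raise the number stays open. So does whether losing this hydroxy would act the same way in compound 2.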